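A few compounds are considered here, and "the series" means these few. Any claim that something is new, unique, unknown or untested is made for them only; others in the source may bear on it.

Measured so far in a functional assay, read by fluorescence and spectrophotometry, with a stated time of 1 h; a lower number here means that less compound is needed, a higher number that more compound is needed for the effect:

- compound 1 `CCCCCCCCS(=O)(=O)/C=C/c1ccc(O)c(O)c1`: 6400 nM
- compound 2 `O=S(=O)(/C=C/c1ccc(O)c(O)c1)CC1CCCC1`: 9400 nM

Among the measured compounds shown here, with only two measured compounds, there is little to place compound 2 against. For the measured compounds named here, its only neighbour is compound 1, and the two differ by no more than repeat measurements usually do: a 1.5-fold higher number from compound 1 to compound 2 (0.17 log units; within the scatter). That step put cyclopentyl in place of heptyl on a saturated chain carbon bound to a sulfonyl sulfur.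

The next compound, compound 3 `C=CCCCCCS(=O)(=O)/C=C/c1ccc(O)c(O)c1`, changes that same place, with hex-5-en-1-yl in place of cyclopentyl on a saturated chain carbon bound to a sulfonyl sulfur. Going by the values given here, the ring goes and an open chain returns, as in compound 1, but this chain ends differently, and no measured compound carries this group. Among the compounds with values here, the one relevant measurement is therefore the step of a 1.5-fold higher number from compound 1 to compound 2 (0.17 log units; within the scatter), and it is small. On that slim evidence, no change beyond the scatter is expected in this assay, with perhaps a slight drift toward compound 1. The expected step is a 1.3-fold lower number from compound 2 to compound 3 (0.10 log units; within the scatter). Compound 3 is estimated at 7500 nM, with an expected range of 3500 nM to 15000 nM.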

Compound 3, half-maximal effective concentration: 7100 nM
Beside the measured number, compound 3's estimate is 1.1-fold (0.02 log units) above it; the range from low to high includes it.
By their numbers in this assay, from the lowest: compounds 1, 3 and 2 (each within the scatter of the next).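

In this assay, the ring of compound 2 can give way to an open chain ending in a double bond, hex-5-en-1-yl, with only a 1.3-fold lower number from compound 2 to compound 3 (0.12 log units; within the scatter), so the cyclopentyl ring shows no sign of being needed at this place. The new compound also allows a comparison within the open chains: vinyl in place of propyl at the chain end gives a 1.1-fold higher number from compound 1 to compound 3 (0.05 log units; within the scatter), so the double bond makes no measurable difference here, and heptyl, cyclopentyl and hex-5-en-1-yl, all made of carbon only, give matching results on a saturated chain carbon bound to a sulfonyl sulfur. No supporting data are available to explain why these groups read alike.

These compounds leave open whether any change at this place can move the number beyond the usual scatter, since all three groups are of similar size and contain only carbon. A much shorter chain such as methyl, or a chain ending in an amine or a carboxylic acid, would test how far this apparent tolerance extends.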